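Swapping a Nitro Group for a Phenol on a Shared Core

The source may hold more compounds than are shown below. What is called first, only, known or untested is meant among the compounds shown, and "the series" means these compounds.

Compound 1 `O=C(CSc1nnnn1-c1cccc2ccccc12)N/N=C/c1cccc(Cl)c1`: 240000 nM
Compound 2 `O=C(CSc1nnnn1-c1cccc2ccccc12)N/N=C/c1ccc([N+](=O)[O-])cc1`: >= 260000 nM
Compound 3 `COc1ccc(O)c(/C=N/NC(=O)CSc2nnnn2-c2cccc3ccccc23)c1`: 4510 nM

Three compounds share one core and differ only in the aromatic group attached to a carbon that carries a double bond to nitrogen. All three were tested in an ADME assay on MT4 cells (Homo sapiens) for cytotoxicity, read by MTT assay; a lower number here means that less compound is tolerated, a higher number that more compound is tolerated. For compound 2 the readout is a limit rather than a number, (the limit of >= 260000 nM in this assay, at which 1 of the 3 values shown sits). Going from compound 1 to compound 2 gives an at least 1.0-fold higher number from compound 1 to compound 2 (0.03 log units; that floor lies within the scatter), a step that stays within the usual scatter. The picture changes with compound 3: the step of a 53-fold lower number from compound 1 to compound 3 (1.73 log units; beyond the scatter) and the step of an at least 57-fold lower number from compound 2 to compound 3 (1.76 log units; beyond the scatter) are both large, and both go in the direction of less compound being tolerated.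

Compound 4 `O=C(CSc1nnnn1-c1cccc2ccccc12)N/N=C/c1ccccc1O` has not yet been measured in this assay. It differs from compound 2 in one place: 2-hydroxyphenyl in place of 4-nitrophenyl on a carbon with a double bond to nitrogen. The entering 2-hydroxyphenyl carries the same hydroxy as the 2-hydroxy-5-methoxyphenyl of compound 3, but not the methoxy. Since the comparable change from compound 2 to compound 3 gave an at least 57-fold lower number from compound 2 to compound 3 (1.76 log units; beyond the scatter), a large drop is expected here too, estimated as an at least 17-fold lower number from compound 2 to compound 4 (1.23 log units; beyond the scatter). Compound 4 is therefore expected to come in at 15000 nM, with a plausible range from 3000 nM to 120000 nM.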

Compound 4, half-maximal cytotoxic concentration: 4850 nM
Beside the measured number, compound 4's estimate is 3.1-fold (0.49 log units) above it; the measured number falls inside the stated range.
By their numbers in this assay, from the lowest: compounds 3 and 4 (each within the scatter of the next); then compound 1. At a limit, above all of these: compound 2.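

In this assay, hydrogen in place of the methoxy of compound 3 leaves the reading within the scatter, with a 1.1-fold higher number from compound 3 to compound 4 (0.03 log units; within the scatter), so the large drop seen earlier does not depend on that methoxy. The simpler 2-hydroxyphenyl group is enough to give a large drop from the 3-chlorophenyl group, with a 49-fold lower number from compound 1 to compound 4 (1.69 log units; beyond the scatter). The same holds against the 4-nitrophenyl group, with an at least 53-fold lower number from compound 2 to compound 4 (1.72 log units; beyond the scatter), but this step starts from a limit rather than a number for compound 2: the limit of >= 260000 nM in this assay, at which 1 of the 4 values shown sits.

The compounds shown leave open whether the hydroxy itself matters or whether another group on the ring would give an equally low number, which a 2-aminophenyl group in the same place could test. As far as these compounds go, it also remains open whether the hydroxy must sit where it does in the 2-hydroxyphenyl group, a question that a 4-hydroxyphenyl group on the carbon with a double bond to nitrogen could help to answer.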